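Ethoxy to butoxy on the shared core

The compounds below may be only part of what the source reports. "The series", "measured", "known", "first", "only" and "open" are said of these compounds alone.

Compound 1 `COc1cccc(-c2[nH]c3ccc(OC)cc3c2C2=C(Br)C(=O)NC2=O)c1` gives 2.79 in a physicochemical assay for lipophilicity (on this read-out higher numbers stand for higher lipophilicity and lower numbers for lower lipophilicity), and compound 2 `CCOc1ccc2[nH]c(-c3cccc(OC)c3)c(C3=C(Br)C(=O)NC3=O)c2c1` gives 2.97 in this assay. Of these two numbers compound 2 holds the higher, though the step of a number 0.18 log units higher from compound 1 to compound 2 (within the scatter) stays within the scatter. Compound 3 `CCCCOc1ccc2[nH]c(-c3cccc(OC)c3)c(C3=C(Br)C(=O)NC3=O)c2c1` carries ethyl in place of hydrogen on a saturated chain carbon, two bonds along the chain from an oxygen on an aromatic ring. Among the compounds with values here, only that single measured step bears on this change, and it was within the scatter, so the entering ethyl has no measured precedent of its own size. An increase beyond the scatter is nonetheless expected, estimated as a number 0.88 log units higher from compound 2 to compound 3 (beyond the scatter). Compound 3 is accordingly expected to give 3.85, within a range of 3.4 to 4.3.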

Compound 3, partition coefficient: 3.46
Compound 3: the middle estimate sits 0.39 log units above what was measured; low and high end bracket the measured number.
By their numbers in this assay, from the lowest: compounds 1 and 2 (each within the scatter of the next); then compound 3.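

At this position, ethoxy to butoxy gives a step beyond the scatter in this assay (a number 0.49 log units higher from compound 2 to compound 3 (beyond the scatter)), which the smaller methyl change did not. Measured against the methoxy compound, the same chain gives a somewhat larger step, also beyond the scatter (a number 0.67 log units higher from compound 1 to compound 3 (beyond the scatter)). No supporting data account for the size of either step.

Going by these compounds, whether a longer chain such as hexyloxy would raise the number further remains open. So does where a butoxy chain ending in an amine or a carboxylic acid would fall in this assay.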